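A Flat Series Meets a Dimethylamino Group

This account rests on a few compounds, and the source may have more. Where it says the series, first, only, none or still open, it means among the compounds named here.

compound 1 `C/C(=N\NC(=O)/C(C#N)=C/c1ccccc1)c1c(O)c2ccc(O)cc2oc1=O`: 55500 nM
compound 2 `COc1cc(/C=C(\C#N)C(=O)N/N=C(\C)c2c(O)c3ccc(O)cc3oc2=O)ccc1O`: 55400 nM
compound 3 `COc1cc(/C=C(\C#N)C(=O)N/N=C(\C)c2c(O)c3ccc(O)cc3oc2=O)cc(OC)c1OC`: 55300 nM

All three numbers come from a functional assay on NRK-49F cells (Rattus norvegicus) for cytotoxicity, read by MTT assay, with a stated time of 24 h; on this read-out lower numbers stand for stronger inhibition and higher numbers for weaker inhibition. Compound 2, at 55400 nM, stands level with the other two, since compound 1 and compound 3 both lie within the usual scatter of it.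

Compound 4 `C/C(=N\NC(=O)/C(C#N)=C/c1ccc(N(C)C)cc1)c1c(O)c2ccc(O)cc2oc1=O` has not been measured yet. It carries 4-(dimethylamino)phenyl in place of the 4-hydroxy-3-methoxyphenyl of compound 2, on a double-bonded chain carbon bound to a double-bonded chain carbon: 4-(dimethylamino)phenyl in place of 4-hydroxy-3-methoxyphenyl on a double-bonded chain carbon bound to a double-bonded chain carbon.

Within the data shown here, the one measured step at this place is a 1.0-fold lower number from compound 1 to compound 2 (0.00 log units; within the scatter), which put 4-hydroxy-3-methoxyphenyl where compound 1 has phenyl. Compound 3 also differs from compound 2 at this place, and compound 3 at 55300 nM stays within the scatter of compound 2. So far, then, changes here have not moved the number in this assay. Among the measured compounds shown here, no measured compound carries the dimethylamino group, however, so this evidence is indirect.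

No shift beyond the scatter is expected, and the expected change is a 1.0-fold lower number from compound 2 to compound 4 (0.00 log units; within the scatter). For compound 4 the estimated value is 55000 nM, with an expected range from 28000 nM to 100000 nM.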

Compound 4, half-maximal inhibitory concentration: 53400 nM
Beside the measured number, compound 4's estimate is 1.0-fold (0.01 log units) above it; measured number inside the range.
By their numbers in this assay, from the lowest: compounds 4, 3, 2 and 1 (each within the scatter of the next).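

In this assay, among these compounds, the dimethylamino group gives the first direct reading of a nitrogen-bearing substituent at this place, and the number does not move beyond the scatter (a 1.0-fold lower number from compound 2 to compound 4 (0.02 log units; within the scatter)). Measured against the unsubstituted phenyl, dimethylamino in place of hydrogen on an aromatic carbon also stays within the scatter (a 1.0-fold lower number from compound 1 to compound 4 (0.02 log units; within the scatter)). The swap from compound 2 to compound 4 also exchanges a group with 1 hydrogen-bond donor and 2 hydrogen-bond acceptors for one with 0 donors and 1 acceptor, yet the four compounds stand level, and no supporting measurement is available to explain this flatness.

As far as these compounds go, all four compounds keep a six-membered aromatic ring of carbon only at this place, so it remains open whether a carboxylic acid on that ring, or a saturated cyclohexyl ring or a longer alkyl chain in place of it, would shift the number. From the compounds shown here alone, the compounds also share the nitrile and the rest of the core, so the effect of changes elsewhere on the molecule remains unknown.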